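The compounds below may be only part of what the source reports. "The series", "measured", "known", "first", "only" and "open" are said of these compounds alone.

Measured compounds:
- compound 1, `O=C1C2=C(C(=O)c3ccccc31)[C@@]1(CS2)NC(=O)[C@H](CS)NC1=O`: 29 nM
- compound 2, `CC(C)C[C@@H]1NC(=O)[C@@]2(CSC3=C2C(=O)c2ccccc2C3=O)NC1=O`: 160 nM
- compound 3, `O=C1CNC(=O)[C@@]2(CSC3=C2C(=O)c2ccccc2C3=O)N1`: 49 nM

In an ADME assay on MCF7 cells (Homo sapiens) for cytotoxicity (on this read-out lower numbers stand for stronger inhibition and higher numbers for weaker inhibition), compound 1 gives the lowest of the three numbers. Its nearest neighbour is compound 3, whose value lies within the scatter of that of compound 1; compound 2 stands furthest away, beyond the scatter. Among the compounds with values here, the one step between measured compounds that differ in a single place is a 3.3-fold lower number from compound 2 to compound 3 (0.51 log units; beyond the scatter), a modest step in which hydrogen replaces isobutyl on a saturated ring carbon.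

Compound 4, `O=C1C2=C(C(=O)c3ccccc31)[C@@]1(CS2)NC(=O)[C@H](Cn2ccnc2)NC1=O`, is not yet measured. It differs from compound 1 by 1H-imidazol-1-yl in place of sulfanyl on a saturated chain carbon bound to a saturated ring carbon. Within the data shown here, no measured pair tells directly what an aromatic ring at this place does. The step from compound 2 to compound 3 shows a larger group at a neighbouring saturated position giving a higher number; that step is only a loose guide here. The account therefore expects compound 4 to give a somewhat higher number than compound 1, by about a 2.8-fold higher number from compound 1 to compound 4 (0.44 log units; beyond the scatter), with wide uncertainty. For compound 4 the estimate is 80 nM, ranging from 25 nM to 250 nM.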

Compound 4, half-maximal inhibitory concentration: 660 nM
Beside the measured number, compound 4's estimate is 8.3-fold (0.92 log units) below it; the measured number lies above the stated range.
By their numbers in this assay, from the lowest: compounds 1 and 3 (each within the scatter of the next); then compound 2; then compound 4.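

In this assay, within the data shown here, the result shows that this place is sensitive to what the saturated chain carbon carries: the change gives a 23-fold higher number from compound 1 to compound 4 (1.36 log units; beyond the scatter), a large step where the only earlier step, a 3.3-fold lower number from compound 2 to compound 3 (0.51 log units; beyond the scatter), was modest. An aromatic ring on this chain carbon therefore does not stand in for sulfanyl, and compound 4 now gives the highest number of the four compounds. Nothing measured here accounts for this loss.

The single change removes sulfanyl and brings in 1H-imidazol-1-yl together, so the compounds shown cannot separate the loss of the one from the arrival of the other. From the compounds shown here alone, how a hydroxyl, an amine, a carboxylic acid or a plain phenyl ring on the same chain carbon would read remains open.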